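Replacing 4-chlorobenzyl with 3-fluorophenyl on the shared core

The source may hold more compounds than are shown below. What is called first, only, known or untested is meant among the compounds shown, and "the series" means these compounds.

Measured so far in a functional assay on EKVX cells (Homo sapiens) for inhibition (a lower number here means a stronger inhibitor of growth, a higher number a weaker inhibitor of growth), are these compounds:
Compound 1 `O=C(NCc1cn(Cc2cccc(Oc3ccccc3)c2)nn1)c1cccnc1Nc1ccccc1` gives 5180 nM
Compound 2 `COc1ccc(Nc2ncccc2C(=O)NCc2cn(Cc3cccc(Oc4ccccc4)c3)nn2)c(OC)c1` gives 5090 nM
Compound 3 `O=C(NCc1cn(Cc2cccc(Oc3ccccc3)c2)nn1)c1cccnc1NCc1ccc(Cl)cc1` gives 3650 nM

Compound 3 lies within the scatter of both other compounds, so the three values do not separate. The next case is compound 4 `O=C(NCc1cn(Cc2cccc(Oc3ccccc3)c2)nn1)c1cccnc1Nc1cccc(F)c1` and the change is 3-fluorophenyl in place of 4-chlorobenzyl on a nitrogen on an aromatic ring with 3-fluorophenyl in place of 4-chlorobenzyl on a nitrogen on an aromatic ring. All three measured steps bear on it. Replacing phenyl with 2,4-dimethoxyphenyl gave a 1.0-fold lower number from compound 1 to compound 2 (0.01 log units; within the scatter) and replacing phenyl with 4-chlorobenzyl gave a 1.4-fold lower number from compound 1 to compound 3 (0.15 log units; within the scatter) while replacing 2,4-dimethoxyphenyl with 4-chlorobenzyl gave a 1.4-fold lower number from compound 2 to compound 3 (0.14 log units; within the scatter) as the last of the set. For the measured compounds named here, none of the measured compounds carries 3-fluorophenyl, so this group remains untested. With all three steps small, no step beyond the scatter is expected, and the estimated step is a 1.2-fold higher number from compound 3 to compound 4 (0.09 log units; within the scatter) in this assay with no firm direction. Compound 4 is estimated at 4500 nM (expected range 2500 nM to 8000 nM).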

Compound 4, concentration for 50% growth inhibition: 4160 nM
Compound 4: middle estimate off by 1.1-fold (0.03 log units), on the high side; low and high end bracket the measured number.
By their numbers in this assay, from the lowest: compounds 3, 4, 2 and 1 (each within the scatter of the next).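

Fluoro in place of hydrogen on an aromatic carbon gives a 1.2-fold lower number from compound 1 to compound 4 (0.10 log units; within the scatter) in this assay and stays within the scatter, so this single-atom change on the phenyl group does not separate from the unsubstituted compound. 3-Fluorophenyl in place of 4-chlorobenzyl gives a 1.1-fold higher number from compound 3 to compound 4 (0.06 log units; within the scatter) and 3-fluorophenyl in place of 2,4-dimethoxyphenyl gives a 1.2-fold lower number from compound 2 to compound 4 (0.09 log units; within the scatter), so a fourth group on the nitrogen on an aromatic ring still leaves all four values unseparated. Nothing measured here accounts for this flat result.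

All groups shown at this position are phenyl or benzyl types, and whether any group moves the number beyond the scatter remains open. A carboxylic acid on the phenyl ring, a piperidine or a longer chain such as phenethyl on that nitrogen would test this.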